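The source may hold more compounds than are shown below. What is called first, only, known or untested is meant among the compounds shown, and "the series" means these compounds.

Of the compounds shown here, two built on the same core have been measured so far. Compound 1 `CC(C)(C)OC(=O)N1CCC[C@H]1C(=O)N1CCC(NS(=O)(=O)c2cc(S(=O)(=O)c3ccccc3)ccc2C(F)(F)F)CC1` gives 60 nM in an assay on isolated protein for binding affinity to secreted frizzled-related protein 1 (Homo sapiens), read by fluorescence (a higher number here means a weaker inhibitor, a lower number a stronger inhibitor), the lower of the two numbers. Compound 2 `CC(C)(C)OC(=O)N1C(=O)CC[C@H]1C(=O)N1CCC(NS(=O)(=O)c2cc(S(=O)(=O)c3ccccc3)ccc2C(F)(F)F)CC1` gives 130 nM in this assay, a higher number that lies beyond the usual scatter. Compound 3 `CC(C)C(=O)N1CCC[C@H]1C(=O)N1CCC(NS(=O)(=O)c2cc(S(=O)(=O)c3ccccc3)ccc2C(F)(F)F)CC1` has not yet been measured; it differs from compound 1 by isopropyl in place of tert-butoxy on a carbonyl carbon. Among the compounds with values here, no measured pair shows a change of this kind. The step is therefore expected to be only about a 1.5-fold higher number from compound 1 to compound 3 (0.18 log units; within the scatter). Compound 3 is therefore estimated at 90 nM, with a range from 35 nM to 250 nM.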

Compound 3, half-maximal inhibitory concentration: 40 nM
Estimate against measurement, compound 3: 2.3-fold (0.35 log units) above; the range from low to high includes it.
By their numbers in this assay, from the lowest: compounds 3 and 1 (each within the scatter of the next); then compound 2.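

Replacing tert-butoxy with isopropyl on this carbonyl carbon gives a 1.5-fold lower number from compound 1 to compound 3 (0.18 log units; within the scatter) in this assay and so leaves the reading unresolved from compound 1. At this position, then, a group of 5 heavy atoms with 1 hydrogen-bond acceptor can give way to one of 3 heavy atoms with no acceptor, without a change that stands clear of the scatter. Nothing measured here explains why these two compounds read alike.

Still open, as far as these compounds go, is how far this tolerance extends: whether a longer chain, an amine or a carboxylic acid on this carbonyl carbon would keep the number in the same range.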